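A few compounds are considered here, and "the series" means these few. Any claim that something is new, unique, unknown or untested is made for them only; others in the source may bear on it.

Working notes on the series:

- Compound 1 `CN(c1cccc2c1CN(c1nc(Nc3cc(C(F)(F)F)cc(C(F)(F)F)c3)ncc1C(F)(F)F)C2)S(C)(=O)=O`: > 30000 nM
- Compound 2 `CN(c1cccc2c1CN(c1nc(Nc3ccc(Cl)c(C(F)(F)F)c3)ncc1C(F)(F)F)C2)S(C)(=O)=O`: > 50000 nM

In a functional assay on OVCAR-3 cells (Homo sapiens) for antiproliferative activity, read by spectrophotometry, with a stated time of 2 days (a higher number here means a weaker inhibitor of growth, a lower number a stronger inhibitor of growth), compound 2 gives > 50000 nM, and this is a limit of the assay, not a number. Compound 1 gives > 30000 nM, which is also a limit. Within the data shown here, no numerical value is therefore available yet for either compound, and no measured step exists.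

Compound 3 `CN(c1cccc2c1CN(c1nc(Nc3cc(Cl)cc(C(F)(F)F)c3)ncc1C(F)(F)F)C2)S(C)(=O)=O` remains unmeasured. It carries 3-chloro-5-(trifluoromethyl)phenyl in place of 4-chloro-3-(trifluoromethyl)phenyl on a nitrogen on an aromatic ring, the rest of the structure being shared with compound 2 (3-chloro-5-(trifluoromethyl)phenyl in place of 4-chloro-3-(trifluoromethyl)phenyl on a nitrogen on an aromatic ring).

With only limits to go on, no change beyond the scatter is expected in this assay, and no direction is favoured. The expected step is an at least 1.2-fold lower number from compound 2 to compound 3 (0.09 log units; that floor lies within the scatter). For compound 3 the estimate is 40000 nM, with an expected range of 12000 nM to 100000 nM.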

Compound 3, concentration for 50% growth inhibition: 21500 nM
The estimate for compound 3 lay 1.9-fold (0.27 log units) above the measured number, and the stated range covers the measured number.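

In this assay, among these compounds, compound 3 is the first of the series to give a number rather than a limit, and with the same atoms joined differently, 3-chloro-5-(trifluoromethyl)phenyl in place of 4-chloro-3-(trifluoromethyl)phenyl on the nitrogen gives an at least 2.3-fold lower number from compound 2 to compound 3 (0.36 log units; beyond the scatter). Chloro in place of trifluoromethyl on an aromatic carbon gives an at least 1.3-fold lower number from compound 1 to compound 3 (0.14 log units; that floor lies within the scatter), and this floor alone does not show a change beyond the scatter, as it is read from the limit of compound 1: the limit of > 30000 nM in this assay, at which 1 of the 3 values shown sits. The first step is likewise only a floor, read from the limit of compound 2: the limit of > 50000 nM in this assay, at which 1 of the 3 values shown sits.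

From the compounds shown here alone, the true size of both steps stays open. So does whether the number moves with a nitrile or a methoxy group in place of chloro on the 3-chloro-5-(trifluoromethyl)phenyl group.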